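Capping the Phenol of Compound 3 with an Ester Arm

The source may hold more compounds than are shown below. What is called first, only, known or untested is meant among the compounds shown, and "the series" means these compounds.

Three amides have been run in an assay on microsomes from intestine for inhibition of acyl-CoA:cholesterol acyltransferase (Oryctolagus cuniculus); on this read-out higher numbers stand for weaker inhibition and lower numbers for stronger inhibition. Compound 1 `CCCCCCCC/C=C/CCCCCCCC(=O)Nc1ccc(F)cc1F` gives 32000 nM, compound 2 `C=C(CCCCCCCCCC)C(=O)Nc1c(OC)cc(OC)cc1OC` gives 200 nM, and compound 3 `CCCCCCCCCCC(C)(C)C(=O)Nc1c(O)cc(OC)cc1OC` gives 590 nM. Compound 3 therefore sits second highest of the three, with compound 2 showing a lower number and compound 1 a far higher one.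

Compound 4 `CCCCCCCCCCC(C)(C)C(=O)Nc1c(OC)cc(OC)cc1OCC(=O)OC` differs from compound 3 only by (methoxycarbonyl)methyl in place of hydrogen on an oxygen on an aromatic ring. For the measured compounds named here, the only measured neighbour with the aromatic oxygen capped, compound 2, carries a different acyl chain, so no clean comparison exists. Given that compound 2 gives 200 nM, a step of a 1.5-fold lower number from compound 3 to compound 4 (0.17 log units; within the scatter) is expected, of modest size toward a somewhat lower number. Compound 4 is estimated at 400 nM, within 120 nM to 1500 nM.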

Compound 4, half-maximal inhibitory concentration: 2300 nM
Compound 4: the middle estimate sits 5.8-fold (0.76 log units) below what was measured; the whole stated range lies below it.
By their numbers in this assay, from the lowest: compound 2; then compound 3; then compound 4; then compound 1.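

Placing (methoxycarbonyl)methyl in place of hydrogen on the oxygen on the aromatic ring brings a 3.9-fold higher number from compound 3 to compound 4 (0.59 log units; beyond the scatter) and so weaker inhibition, a loss beyond the scatter. For the compounds shown here, this gives the first clean reading at this position: with the acyl chain held constant, the free hydroxy outperforms the ester arm, which compound 2 could not show. No available evidence bears on the reason for this step.

Open, from the compounds shown here alone, is how a plain methoxy on the acyl chain of compound 3 would compare. Also open, going by these compounds, is whether a carboxylic acid in place of the methyl ester would recover inhibition.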